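The compounds below may be only part of what the source reports. "The series", "measured", "known", "first", "only" and "open" are said of these compounds alone.

Measured so far:
- compound 1 `O=C(/C=C/c1ccc([N+](=O)[O-])o1)c1ccc(Br)cc1`: 85400 nM
- compound 2 `O=C(/C=C/c1ccc([N+](=O)[O-])o1)c1ccc(I)cc1`: 68200 nM
- compound 3 `CCCCc1ccc(C(=O)/C=C/c2ccc([N+](=O)[O-])o2)cc1`: 41200 nM

In an ADME assay on cells (Astrocyte, Rattus norvegicus, strain Wistar) for inhibition, read by sulforhodamine B assay, with a stated time of 72 h (on this read-out lower numbers stand for higher toxicity in this test and higher numbers for lower toxicity in this test), compound 3 gives 41200 nM. That number lies within the scatter of compound 2, as a 1.7-fold lower number from compound 2 to compound 3 (0.22 log units; within the scatter) shows, and apart from compound 1, as a 2.1-fold lower number from compound 1 to compound 3 (0.32 log units; beyond the scatter) shows. The next structure is compound 4 `O=C(/C=C/c1ccc([N+](=O)[O-])o1)c1ccc(-n2ccnc2)cc1`, and the change is this: 1H-imidazol-1-yl in place of butyl on an aromatic carbon. In words, 1H-imidazol-1-yl comes in place of butyl on an aromatic carbon.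

The three measured steps all swap one group at this same place. Besides the two above, there is a 1.3-fold lower number from compound 1 to compound 2 (0.10 log units; within the scatter). All three are small, but none brings in 1H-imidazol-1-yl, so the data offer only indirect guidance. A large change is therefore not expected, only a slight lean back toward compound 1 at 85400 nM and compound 2 at 68200 nM. The expected move is a 1.5-fold higher number from compound 3 to compound 4 (0.16 log units; within the scatter), most likely within the scatter. The estimate for compound 4 is 60000 nM, with an expected range of 25000 nM to 120000 nM.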

Compound 4, half-maximal cytotoxic concentration: 45300 nM
Estimate against measurement, compound 4: 1.3-fold (0.12 log units) above; the range from low to high includes it.
By their numbers in this assay, from the lowest: compounds 3, 4, 2 and 1 (each within the scatter of the next, the first and the last beyond it).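

In this assay, swapping the butyl chain for 1H-imidazol-1-yl, a five-membered aromatic ring with two nitrogens, gives a 1.1-fold higher number from compound 3 to compound 4 (0.04 log units; within the scatter) and so leaves the number effectively unchanged. The new compound also sits close to both halogen compounds, with a 1.5-fold lower number from compound 2 to compound 4 (0.18 log units; within the scatter) and a 1.9-fold lower number from compound 1 to compound 4 (0.28 log units; within the scatter), so a ring with hydrogen-bond acceptors at this place gives a number within the scatter of those for a bromo, an iodo and a butyl group. No measurement at hand explains this result.

Still open, as far as these compounds go, is whether an amine, a carboxylic acid or a longer chain at this place would stay within the same narrow band of values. Also open, from the compounds shown here alone, is whether a second imidazole nitrogen matters at all, which a plain phenyl ring in the same place could help to test.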